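The source may report more compounds than this note shows. Statements on the series, on what has been measured and on what is new or still open speak of the compounds shown alone.

Measured so far:
compound 1, `CCOC(=O)c1ccc(-c2nn(C)c3ccccc23)cc1`, > 10000 nM
compound 2, `CCOC(=O)c1ccc(-c2nn(-c3ccco3)c3ccccc23)cc1`, > 10000 nM
compound 3, `CC(C)OC(=O)c1ccc(-c2nn(Cc3ccccc3)c3ccccc23)cc1`, > 10000 nM

In a functional assay on cells (Platelet, Homo sapiens) for inhibition (a lower number here means a stronger inhibitor, a higher number a weaker inhibitor), compound 1 gives > 10000 nM, which is a limit of the assay and not a number. Compound 2, in this assay, gives > 10000 nM, again a limit. For the measured compounds named here, the one step between measured compounds, a step that the two limits leave unreadable from compound 1 to compound 2, therefore cannot be read. Compound 3 likewise stands at a limit in this assay, with > 10000 nM, so all three values shown sit at the limit of > 10000 nM in this assay, at which 3 of the 3 values shown sit, and none of them is a number.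

Compound 4, `CCOC(=O)/C=C/c1ccc(-c2nn(Cc3ccccc3)c3ccccc23)cc1`, is not yet measured. It differs from compound 3 by 2-(ethoxycarbonyl)ethenyl in place of isopropoxycarbonyl on an aromatic carbon. Going by the values given here, no measured step touches this part of the molecule, and the only step known, between compound 1 and compound 2, is itself unreadable, so there is no size of step to carry over. With compound 3 at a limit, the expectation for compound 4 rests on that limit alone.

Compound 4 is expected to give about 15000 nM in this assay, most likely again as a limit, with a range from 5000 nM to 50000 nM. The step that the limit leaves unreadable from compound 3 to compound 4 is thus estimated as none readable beyond the scatter.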

Compound 4, half-maximal inhibitory concentration: > 10000 nM
Compound 4: only a limit was reported; the forecaster's own chance of this, stated with the estimate: 80%; the middle value lies beyond the limit too.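

Compound 3 and compound 4 both stand at a limit in this assay and not at a number, so no step can be read from one to the other. The compounds shown leave open how strongly any of them inhibits and what any change of group does to the value, because all share one limit: the limit of > 10000 nM in this assay, at which 4 of the 4 values shown sit.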